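Aryl Exchanges Leave a Cytotoxicity Reading Unmoved

The source may report more compounds than this note shows. Statements on the series, on what has been measured and on what is new or still open speak of the compounds shown alone.

In a functional assay on B16-F10 cells (Mus musculus) for cytotoxicity (a higher number here means a weaker inhibitor, a lower number a stronger inhibitor), compound 3 `O=c1oc2ccccc2c2nc3c(ccc4cc[nH]c43)c(-c3ccc([N+](=O)[O-])cc3)c12` gives 70700 nM. Among the measured compounds shown here, that is the same reading as compound 1 `O=c1oc2ccccc2c2nc3c(ccc4cc[nH]c43)c(-c3cccc4ccccc34)c12` at 70700 nM and compound 2 `O=c1oc2ccccc2c2nc3c(ccc4cc[nH]c43)c(-c3c(Cl)cccc3Cl)c12` at 70700 nM, so compound 3 stands level with both, and no member of the trio can be ranked above another. The next compound, compound 4 `O=c1oc2ccccc2c2nc3c(ccc4cc[nH]c43)c(-c3ccccc3Br)c12`, keeps the shared core and carries 2-bromophenyl in place of 4-nitrophenyl on an aromatic carbon, opposite the ring nitrogen: 2-bromophenyl in place of 4-nitrophenyl on an aromatic carbon. Three measured steps exchange the group at this same place, and all of them bear on the new change: no change at the digits printed from compound 1 to compound 2 (within the scatter), no change at the digits printed from compound 1 to compound 3 (within the scatter) and no change at the digits printed from compound 2 to compound 3 (within the scatter). None of these exchanges moved the reading, and the last two include the departure or arrival of 4-nitrophenyl itself. For the measured compounds named here, no compound with 2-bromophenyl has been measured, so this remains an extrapolation from three aryl groups. On that evidence, no shift beyond the scatter is expected in this assay, in either direction. The expected step is no change at the digits printed from compound 3 to compound 4 (within the scatter). For compound 4 the estimated value is 70700 nM, with an expected range from 30000 nM to 100000 nM.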

Compound 4, half-maximal inhibitory concentration: 70700 nM
For compound 4 middle estimate and measured number coincide at the digits printed; measured number inside the range.
By their numbers in this assay, from the lowest: compounds 1, 2, 3 and 4 (each within the scatter of the next).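

The exchange opposite the ring nitrogen extends the flat result to a group of a different make-up: in this assay, 2-bromophenyl, with a bromine and without hydrogen-bond acceptors, replaces 4-nitrophenyl, which carries them along with a double bond outside the aromatic ring, and the outcome is no change at the digits printed from compound 3 to compound 4 (within the scatter). The readings against the other two groups agree, with no change at the digits printed from compound 2 to compound 4 (within the scatter) for the exchange of 2,6-dichlorophenyl and no change at the digits printed from compound 1 to compound 4 (within the scatter) for the exchange of naphthalen-1-yl, so all four aryl groups at this position now sit within the scatter of one another and none can be ranked above another. Nothing available explains why these exchanges leave the reading in place.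

Going by these compounds, all four groups are aromatic rings of carbon attached directly at this position, so it remains open whether an amine, a carboxylic acid, a longer alkyl chain or a nitrogen-containing aromatic ring there would shift the reading in this assay. The compounds shown also share one core, which leaves the effect of any change elsewhere on it unknown.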